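Adding a Methyl Group to a Poorly Soluble Amide Series

This account rests on a few compounds, and the source may have more. Where it says the series, first, only, none or still open, it means among the compounds named here.

Of the compounds shown here, three have been measured in a physicochemical assay for solubility, measured as thermodynamic solubility, with a stated time of 24 h, at pH 6.8; on this read-out higher numbers stand for higher solubility and lower numbers for lower solubility. Compound 1 has the structure `Cc1cc(C)c2cc(C(=O)NC3CCCCC3)[nH]c2c1`. In this assay compound 1 gives < 4000 nM, which is a limit of the assay rather than a number. Compound 2, `Cc1cc(C)c2cc(C(=O)N[C@@H]3CCCC[C@@H]3C)[nH]c2c1`, differs from compound 1 by methyl in place of hydrogen on a saturated ring carbon. In this assay compound 2 gives < 4000 nM, again a limit. The step that the two limits leave unreadable from compound 1 to compound 2 therefore cannot be sized, because of the limit of < 4000 nM in this assay, at which 3 of the 3 values shown sit.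

Compound 3 has the structure `CC1CCC(NC(=O)c2cc3c(F)cc(F)cc3[nH]2)CC1`; the difference between its core and the core of compound 1 is not broken down here. In this assay compound 3 gives < 4000 nM, also a limit.

Compound 4, `CC1(C)CCC(NC(=O)c2cc3c(F)cc(F)cc3[nH]2)CC1`, is not yet measured. It differs from compound 3 by methyl in place of hydrogen on a saturated ring carbon. This is the same kind of change as that from compound 1 to compound 2, though in compound 2 the methyl sits next to the ring atom that bears a large group, while in compound 4 it sits three ring bonds from it. Since every value seen so far sits at the limit, the expected step that the limit leaves unreadable from compound 3 to compound 4 rests on little, and compound 4 is estimated to reach about 2000 nM, most likely again reported only as a limit.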

Compound 4, solubility: < 4000 nM
Compound 4 was reported as a limit; the forecaster's own chance of this, stated with the estimate: 85%; the middle value does not contradict the limit.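

The step between compound 3 and compound 4 cannot be read, because both results are limits rather than numbers: the limit of < 4000 nM in this assay, at which 4 of the 4 values shown sit.

The compounds shown leave open what the actual values of all four compounds are, and whether methyl in place of hydrogen on a saturated ring carbon moves the read-out at all.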